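The source may hold more compounds than are shown below. What is called first, only, known or untested is meant among the compounds shown, and "the series" means these compounds.

Working notes on the series. Compound 1 `CC(C)c1n[nH]c2c(NCc3ccc(-c4ccccn4)cc3)nc(SCC(O)CN)nc12` gives 55 nM in a functional assay on HT cells (Homo sapiens) for antiproliferative activity, read by fluorescence, with a stated time of 72 h (on this read-out higher numbers stand for weaker inhibition of growth and lower numbers for stronger inhibition of growth), compound 2 `CC(C)c1n[nH]c2c(NCc3ccc(-c4ccccn4)cc3)nc(SCCCN(C)C)nc12` gives 105 nM, and compound 3 `C=CCSc1nc(NCc2ccc(-c3ccccn3)cc2)c2[nH]nc(C(C)C)c2n1` gives 1010 nM, the highest number of the three. The steps leading to compound 3 are an 18-fold higher number from compound 1 to compound 3 (1.26 log units; beyond the scatter) and a 9.6-fold higher number from compound 2 to compound 3 (0.98 log units; beyond the scatter), while a 1.9-fold higher number from compound 1 to compound 2 (0.28 log units; within the scatter).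

Compound 4 `CC(C)c1n[nH]c2c(NCc3ccc(-c4ccccn4)cc3)nc(SCC(C)(C)N)nc12` differs from compound 3 by 1-amino-1-methylethyl in place of vinyl on a saturated chain carbon bound to a sulfur. A hydrogen-bond donor and acceptor return to the chain on the saturated carbon bound to sulfur, as in compound 1 and compound 2. Both steps onto compound 3 bear on this change and both were beyond the scatter in the same direction, so a drop of comparable size is expected in this assay, though the gap between them leaves the size uncertain. Compound 4 is therefore estimated at 80 nM, with a range from 30 nM to 250 nM, an expected step of a 13-fold lower number from compound 3 to compound 4 (1.10 log units; beyond the scatter).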

Compound 4, concentration for 50% growth inhibition: 85 nM
Estimate against measurement, compound 4: 1.1-fold (0.03 log units) below; the range from low to high includes it.
By their numbers in this assay, from the lowest: compounds 1, 4 and 2 (each within the scatter of the next); then compound 3.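

In this assay the 2-amino-2-methylpropyl chain in place of allyl gives a 12-fold lower number from compound 3 to compound 4 (1.07 log units; beyond the scatter) and makes a third amine-bearing chain that stands apart from allyl on this saturated carbon bound to sulfur. The steps of a 1.2-fold lower number from compound 2 to compound 4 (0.09 log units; within the scatter) and a 1.5-fold higher number from compound 1 to compound 4 (0.19 log units; within the scatter) lie within the scatter, so neither the hydroxyl of compound 1 nor the dimethylamino end of compound 2 is needed to hold this level. No outside data bear on the reason for this.

Open, going by these compounds, is whether the amine itself is required: a chain ending in a hydroxyl without an amine, or in a carboxylic acid, would separate this. Also open, on these data alone, is how a longer amine chain or a cyclic amine such as piperidine would behave here.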